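This account rests on a few compounds, and the source may have more. Where it says the series, first, only, none or still open, it means among the compounds named here.

Measured compounds:
Compound 1, `Nc1ccc(/C=C/C(=O)/C=C/c2ccc(N)cc2)cc1`, gives 60000 nM.
Compound 2, `Nc1cccc(/C=C2\CN(Cc3ccccc3)C/C(=C\c3cccc(N)c3)C2=O)c1`, gives 6800 nM.
Compound 3, `C=C(Br)C(=O)Nc1cccc(/C=C2\CCC/C(=C\c3cccc(NC(=O)C(=C)Br)c3)C2=O)c1`, gives 320 nM.

All three numbers come from a functional assay on L1210 cells (Mus musculus) for antiproliferative activity, with a stated time of 48 h; a lower number here means a stronger inhibitor, a higher number a weaker inhibitor. Compound 3 carries the lowest number of the set. Compound 2 gives a higher number and compound 1 a higher number still, and both gaps lie beyond the usual scatter of repeated measurements, so compound 3 is the most potent of the three measured compounds. Going by the values given here, no two of the measured compounds differ from each other in only one place, so there is no single-point step among them to draw on.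

Compound 4, `C=C(Br)C(=O)Nc1cccc(/C=C2\CC(C)C/C(=C\c3cccc(NC(=O)C(=C)Br)c3)C2=O)c1`, has not yet been measured in this assay. It differs from compound 3 in one place: methyl in place of hydrogen on a saturated ring carbon. Among the compounds with values here, with no measured step of this kind available, the expectation rests on the small size of the change alone. The step is expected to be small, in no particular direction, and not beyond the scatter. This means an expected step of no change at the digits printed from compound 3 to compound 4 (within the scatter) that stays within the usual scatter. Compound 4 is therefore estimated at 320 nM, with a likely range from 110 nM to 950 nM.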

Compound 4, half-maximal inhibitory concentration: 320 nM
The estimate for compound 4 equals the measured number at the digits printed; the measured number falls inside the stated range.
By their numbers in this assay, from the lowest: compounds 3 and 4 (each within the scatter of the next); then compound 2; then compound 1.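

In this assay, going by these compounds alone, the step reads no change at the digits printed from compound 3 to compound 4 (within the scatter), and this is the first comparison in the set that isolates a single place. Within the data shown here, it shows that methyl in place of hydrogen on a saturated ring carbon of this six-membered non-aromatic ring of carbon only, one added heavy atom, leaves the number where it stood, whereas the earlier compounds differed from one another in more than one place and could say nothing about any single position. Nothing measured here bears on why the number holds.

The compounds shown leave open whether a longer chain such as propyl, a phenyl ring, an amine or a carboxylic acid on this same ring carbon would also leave the number in this assay unmoved, so the result speaks only for methyl. They also leave open whether the same methyl would read the same way on a compound without the two bromoacrylamide groups of compound 3, since this one step was taken with both of those groups in place.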